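Swapping a Fluorophenyl Group on a Shared Core

The compounds below may be only part of what the source reports. "The series", "measured", "known", "first", "only" and "open" are said of these compounds alone.

Within the data shown here, compound 2 `CN(C)CCCNc1nc2cc([N+](=O)[O-])ccc2nc1NCc1ccc(F)cc1` is tested in an ADME assay on HEK293 cells (Homo sapiens) for cytotoxicity, read by MTT assay, with a stated time of 24 h (a higher number here means a weaker inhibitor, a lower number a stronger inhibitor), where compound 2 gives 4.28 ug/mL, the only number measured so far. Compound 1 `O=[N+]([O-])c1ccc2nc(NCc3ccc(C(F)(F)F)cc3)c(N3CCCCC3)nc2c1` reaches only a limit in this assay, recorded as > 200 ug/mL. That limit is the limit of > 200 ug/mL in this assay, at which 1 of the 2 values shown sits. Compound 3 `CN(C)CCCNc1nc2cc([N+](=O)[O-])ccc2nc1NCc1ccc(Cl)c(C(F)(F)F)c1` differs from compound 2 in one place: 4-chloro-3-(trifluoromethyl)phenyl in place of 4-fluorophenyl on a saturated chain carbon bound to a nitrogen on an aromatic ring. Among the measured compounds shown here, no measured pair of compounds differs in just one place, so the size of this step cannot be read from the data. For compound 3 a step in this assay of a 1.4-fold lower number from compound 2 to compound 3 (0.15 log units; within the scatter) is expected, toward a stronger inhibitor but hardly beyond the usual scatter. Compound 3 is therefore estimated at 3 ug/mL, between 1 ug/mL and 10 ug/mL.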

Compound 3, half-maximal inhibitory concentration: 3.26 ug/mL
Beside the measured number, compound 3's estimate is 1.1-fold (0.04 log units) below it, and the stated range covers the measured number.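

Putting 4-chloro-3-(trifluoromethyl)phenyl in place of 4-fluorophenyl on a saturated chain carbon bound to a nitrogen on an aromatic ring gives, in this assay, a 1.3-fold lower number from compound 2 to compound 3 (0.12 log units; within the scatter). This position therefore accepts the added chlorine and trifluoromethyl with no real shift in the number. Nothing measured here accounts for that result.

As far as these compounds go, whether a carboxylic acid or an amine on this phenyl ring would move the number remains open. So does the effect of replacing the phenyl ring with a saturated cyclohexyl ring.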